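The source may report more compounds than this note shows. Statements on the series, on what has been measured and on what is new or still open speak of the compounds shown alone.

Compound 1 `O=C(O)c1ccc(C(=O)/C(=C\c2ccc(Br)cc2)SCc2ccc(F)cc2)cc1` is measured in a functional assay on DU-145 cells (Homo sapiens) for inhibition, read by trypan blue exclusion, with a stated time of 96 h (a lower number here means a stronger inhibitor of growth, a higher number a weaker inhibitor of growth), only to a limit: compound 1 gives > 100000 nM there, a limit of the assay rather than a number (the limit of > 100000 nM in this assay, at which 1 of the 2 values shown sits). Compound 2 `O=C(O)c1ccc(C(=O)/C(=C\c2ccc(Cl)c([N+](=O)[O-])c2)SCc2ccc(F)cc2)cc1` gives 1000 nM in this assay, and the change of 4-chloro-3-nitrophenyl in place of 4-bromophenyl brings an at least 100-fold lower number from compound 1 to compound 2 (2.00 log units; beyond the scatter). Compound 3 `O=C(O)c1ccc(C(=O)/C(=C\c2ccc(Br)cc2)SCc2ccc(Br)cc2)cc1` differs from compound 1 elsewhere, at the (4-fluorobenzyl)sulfanyl part: bromo in place of fluoro on an aromatic carbon. For the measured compounds named here, no measured step touches that position, so no step beyond the scatter is expected in this assay, and compound 3 is expected to give 100000 nM (range 30000 nM to 300000 nM), a step of a number no higher from compound 1 to compound 3 (the limit leaves the size open).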

Compound 3, concentration for 50% growth inhibition: 1000 nM
Compound 3: middle estimate off by 100-fold (2.00 log units), on the high side; measured number below the stated range.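

For the compounds shown here, the (4-fluorobenzyl)sulfanyl part, which no earlier step touched, proves to matter in this assay: bromo in place of fluoro on an aromatic carbon brings an at least 100-fold lower number from compound 1 to compound 3 (2.00 log units; beyond the scatter) with a single atom exchanged. This gives a second place, apart from the 4-bromophenyl group, where one change takes compound 1 off its limit. Compound 1 stands only at a limit, so the full size of this step stays open: the limit of > 100000 nM in this assay, at which 1 of the 3 values shown sits.

The compounds shown leave open whether another group, such as chloro, methyl or an amine, would serve at this position. They also leave open what the two changes would do together, and what an ester in place of the carboxylic acid would bring.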